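Swapping a methyl for a phenyl on a quinazolinone-type core

A few compounds are considered here, and "the series" means these few. Any claim that something is new, unique, unknown or untested is made for them only; others in the source may bear on it.

Two compounds share a fused core carrying an aryl ether side arm, and both have been measured in a physicochemical assay for lipophilicity, in phosphate buffer, measured as octanol-water partition; on this read-out lower numbers stand for lower lipophilicity and higher numbers for higher lipophilicity. Compound 1 `Cc1ccc(Oc2ccc(/C=N/n3c(-c4ccccc4)nc4ccccc4c3=O)cc2)cc1` gives 6.29. Compound 2 `Cc1nc2ccccc2c(=O)n1/N=C/c1ccc(Oc2ccccc2)cc1` gives 4.01, the lower of the two numbers, standing well beyond the scatter below compound 1.

Compound 3 `O=c1c2ccccc2nc(-c2ccccc2)n1/N=C/c1ccc(Oc2ccccc2)cc1` has not been measured yet. It differs from compound 2 in one place: phenyl in place of methyl on an aromatic carbon. A phenyl replacing a methyl on an aromatic carbon adds five carbon atoms and a second aromatic ring, which in this assay usually pushes the number upward by a clear margin. The step of a number 1.79 log units higher from compound 2 to compound 3 (beyond the scatter) is therefore expected to be a rise, because compound 1, which also carries the phenyl, gives 6.29. Compound 3 is estimated at 5.8, within a range from 5.2 to 6.4.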

Compound 3, partition coefficient: 6.13
For compound 3 the middle estimate is 0.33 log units below the measured one; the measured number falls inside the stated range.
By their numbers in this assay, from the lowest: compound 2; then compounds 3 and 1 (each within the scatter of the next).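

In this assay, the comparison now isolates one change at the carbon between two ring nitrogen atoms, and phenyl in place of methyl there gives a large step (a number 2.12 log units higher from compound 2 to compound 3 (beyond the scatter)), something compounds 1 and 2 could not show because they differ in two places. A second single change, removal of the methyl from the side arm, gives a step that cannot be told from scatter (a number 0.16 log units lower from compound 1 to compound 3 (within the scatter)), so that methyl leaves no readable mark on this read-out. Nothing available explains why the phenyl step is this large.

The compounds shown carry only methyl and phenyl at this position. Going by these compounds, how an amine, a carboxylic acid or a longer chain there would read in this assay stays open.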